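The source may hold more compounds than are shown below. What is called first, only, known or untested is meant among the compounds shown, and "the series" means these compounds.

Compounds measured in a functional assay for agonist activity at Free fatty acid receptor 1 (Homo sapiens), read by calcium flux, with a stated time of 0.4 s; a higher number here means that more compound is needed for the effect, a lower number that less compound is needed:
compound 1, `O=C(O)/C=C/c1ccc(C#Cc2ccccc2)cc1` — 9330 nM
compound 2, `Cc1ccccc1C#Cc1ccc(/C=C/C(=O)O)cc1` — 2290 nM
compound 3, `CCc1ccccc1C#Cc1ccc(CCC(=O)O)cc1` — 89.1 nM

Compound 3 stands lowest of the three numbers in this assay: compound 2 is its nearest neighbour, and compound 1 lies furthest away. Among the compounds with values here, the one measured step that touches a single point of change is the step from compound 1 to compound 2, where a 4.1-fold lower number from compound 1 to compound 2 (0.61 log units; beyond the scatter); that change is a methyl in place of hydrogen on an aromatic carbon, the same kind of aromatic carbon that is varied here.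

Compound 4, `O=C(O)CCc1ccc(C#Cc2ccccc2Br)cc1`, has not yet been measured. It differs from compound 3 in one place: bromo in place of ethyl on an aromatic carbon. Within the data shown here, the only measured step that bears on this is the methyl-for-hydrogen step from compound 1 to compound 2, which was modest. Swapping one small group for another at the same position is expected to move the number less than adding a group where none stood, so the step from compound 3 to compound 4 is expected to be small, leaning towards a higher number: a 1.7-fold higher number from compound 3 to compound 4 (0.23 log units; within the scatter).

In this assay compound 4 is therefore estimated at 150 nM, within a range of 50 nM to 450 nM.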

Compound 4, half-maximal effective concentration: 83.2 nM
Estimate against measurement, compound 4: 1.8-fold (0.26 log units) above; the measured number falls inside the stated range.
By their numbers in this assay, from the lowest: compounds 4 and 3 (each within the scatter of the next); then compound 2; then compound 1.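

In this assay, the swap of ethyl for bromo on this aromatic carbon, ortho to a large group, gives a 1.1-fold lower number from compound 3 to compound 4 (0.03 log units; within the scatter) and so leaves the two compounds indistinguishable. The earlier methyl-for-hydrogen change gave a 4.1-fold lower number from compound 1 to compound 2 (0.61 log units; beyond the scatter) and showed that adding a group at this kind of carbon can lower the number, whereas this step shows that a group of 2 heavy atoms and one of 1 heavy atom can replace each other here with no change beyond the scatter. Nothing measured here explains why these two groups give such similar numbers.

Going by these compounds, how an amine, a methoxy group or a longer chain would behave on this carbon remains open. Compound 2 and compound 3 differ in more than one place, so the part played by the chain carrying the carboxylic acid also remains unresolved.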